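Furanoyl to fluorobenzoyl amide on a shared quinoline core

The compounds below may be only part of what the source reports. "The series", "measured", "known", "first", "only" and "open" are said of these compounds alone.

Measured compounds in a functional assay on SK-BR-3 cells (Homo sapiens) for antiproliferative activity, read by MTT assay, with a stated time of 72 h; on this read-out higher numbers stand for weaker inhibition and lower numbers for stronger inhibition:
compound 1 `CCN1CCN(c2cc(C)c3cc(NC(=O)c4ccc(OC)cc4)ccc3n2)CC1` gives 9000 nM
compound 2 `CCN1CCN(c2cc(C)c3cc(NC(=O)c4cccnc4)ccc3n2)CC1` gives 10600 nM
compound 3 `CCN1CCN(c2cc(C)c3cc(NC(=O)c4ccco4)ccc3n2)CC1` gives 37500 nM

Compound 3 carries the highest number of the three in this assay: against compound 2 the step is a 3.5-fold higher number from compound 2 to compound 3 (0.55 log units; beyond the scatter), and against compound 1 it is a 4.2-fold higher number from compound 1 to compound 3 (0.62 log units; beyond the scatter), both beyond the scatter, whereas compound 1 and compound 2 sit within the scatter of each other, a 1.2-fold higher number from compound 1 to compound 2 (0.07 log units; within the scatter).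

Compound 4 `CCN1CCN(c2cc(C)c3cc(NC(=O)c4ccc(F)cc4)ccc3n2)CC1` is the next step from compound 3. The change is 4-fluorophenyl in place of furan-2-yl on a carbonyl carbon. Both measured steps that reach compound 3 bear on this: replacing a six-membered aromatic ring with furan-2-yl on the carbonyl carbon raised the number modestly from compound 1 and from compound 2. Compound 4 reverses that kind of change, putting a six-membered aromatic ring of carbon only back in place of furan-2-yl. For the measured compounds named here, no measured pair isolates 4-fluorophenyl against 4-methoxyphenyl, so the exact landing point is open. Compound 4 is therefore expected to show a modest drop in number, a 3.8-fold lower number from compound 3 to compound 4 (0.57 log units; beyond the scatter), to roughly the level of compound 1. The estimate for compound 4 is 10000 nM, with a range from 4500 nM to 25000 nM.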

Compound 4, half-maximal inhibitory concentration: 19800 nM
Estimate against measurement, compound 4: 2.0-fold (0.30 log units) below; measured number inside the range.
By their numbers in this assay, from the lowest: compounds 1, 2, 4 and 3 (each within the scatter of the next, the first and the last beyond it).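

Putting 4-fluorophenyl on the carbonyl carbon in place of furan-2-yl does not separate the two amides in this assay (a 1.9-fold lower number from compound 3 to compound 4 (0.28 log units; within the scatter)), and the 4-fluorophenyl amide is likewise not separated from the pyridin-3-yl amide (a 1.9-fold higher number from compound 2 to compound 4 (0.27 log units; within the scatter)). A six-membered aromatic ring of carbon only at this place therefore does not by itself bring the number to the level of compound 1, since fluoro in place of methoxy on an aromatic carbon gives a modest step beyond the scatter (a 2.2-fold higher number from compound 1 to compound 4 (0.34 log units; beyond the scatter)). The data shown offer no measurement that explains these steps.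

Going by these compounds, whether an unsubstituted phenyl, or a chloro or dimethylamino group in place of the fluoro, would lie nearer compound 1 or compound 4 remains open. So does the effect of a longer chain, such as a benzyl group, on the carbonyl carbon.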